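Swapping a sulfonamide hydrogen for a pyrimidine: toxicity outlook

The compounds below may be only part of what the source reports. "The series", "measured", "known", "first", "only" and "open" are said of these compounds alone.

Of the compounds shown here, three have been measured in an ADME assay on cells (Macrophage, Homo sapiens) for cytotoxicity, read by microscopy and CCK-8 assay, with a stated time of 48 h; on this read-out lower numbers stand for higher toxicity in this test and higher numbers for lower toxicity in this test. Compound 1 `CC(C)(C)c1cc(C(C)(C)C)c2oc(=O)c(/C=N/c3ccc(S(N)(=O)=O)cc3)c(Cl)c2c1` gives 580 nM. Compound 2 `Cc1ccnc(NS(=O)(=O)c2ccc(/N=C/c3c(Cl)c4cc(C(C)(C)C)cc(C(C)(C)C)c4oc3=O)cc2)n1` gives 360 nM. Compound 3 `Cc1ccc2oc(=O)c(/C=N/c3ccc(S(N)(=O)=O)cc3)c(Cl)c2c1` gives 1200 nM, the highest of the three numbers, so it is the least toxic compound measured here. The change from compound 1 to compound 2 is 4-methylpyrimidin-2-yl in place of hydrogen on a sulfonamide nitrogen, and it made a 1.6-fold lower number from compound 1 to compound 2 (0.21 log units; within the scatter). The difference between the core of compound 1 and the core of compound 3 is not broken down here.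

Compound 4 `Cc1ccc2oc(=O)c(/C=N/c3ccc(S(=O)(=O)Nc4nccc(C)n4)cc3)c(Cl)c2c1` is not yet measured. It carries the same change on the core of compound 3: 4-methylpyrimidin-2-yl in place of hydrogen on a sulfonamide nitrogen, at the same place. In this assay, among the compounds with values here, the step from compound 3 to compound 4 is expected to be a 1.5-fold lower number from compound 3 to compound 4 (0.18 log units; within the scatter), resting on the step from compound 1 to compound 2, which is a 1.6-fold lower number from compound 1 to compound 2 (0.21 log units; within the scatter); only one such pair is known, so this rests on thin ground. Compound 4 is estimated at 800 nM, likely between 350 nM and 1800 nM.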

Compound 4, minimum cytotoxic concentration: 560 nM
Compound 4: middle estimate off by 1.4-fold (0.15 log units), on the high side; low and high end bracket the measured number.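

In this assay, within the data shown here, placing 4-methylpyrimidin-2-yl on the sulfonamide nitrogen gave a 2.1-fold lower number from compound 3 to compound 4 (0.33 log units; beyond the scatter), and the comparison with the same change on the other core reads: the same change on two cores in this assay, a 1.6-fold lower number (0.21 log units; within the scatter) from compound 1 to compound 2 and a 2.1-fold lower number (0.33 log units; beyond the scatter) from compound 3 to compound 4, 1.3-fold (0.12 log units) apart, within the scatter of two such steps Only the step on the core of compound 3 lies beyond the scatter, yet the gap between the two steps does not, so the change can be read as carrying over between these two cores with a similar size. Two pairs do not make a rule, however: they do not show that the change would behave this way on a third core, and they do not explain why the numbers fall where they do.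

The compounds shown leave open whether a different group on the sulfonamide nitrogen, such as an acetyl group or a thiazole ring, would give a similar step. They also leave open whether the methyl on the pyrimidine matters, which a plain pyrimidin-2-yl group could test.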